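The compounds below may be only part of what the source reports. "The series", "measured", "known", "first", "only" and "open" are said of these compounds alone.

Working notes on the chain series, read in a functional assay on MDA-MB-231 cells (Homo sapiens) for inhibition, read by MTT assay, with a stated time of 72 h; on this read-out lower numbers stand for stronger inhibition and higher numbers for weaker inhibition. Compound 1 `Nc1ncnc2c1c(-c1cnc3[nH]ccc3c1)nn2CCCCCCCCC(=O)NO` gives 11000 nM. Compound 2 `Nc1ncnc2c1c(-c1cnc3[nH]ccc3c1)nn2CCCCCC(=O)NO` gives > 100000 nM, which is a limit of the assay and not a number. Compound 2 therefore has no exact position, and what stands for it is the limit of > 100000 nM in this assay, at which 1 of the 2 values shown sits.

Next in line is compound 3 `Nc1ncnc2c1c(-c1cnc3[nH]ccc3c1)nn2CCC(=O)NO`, with the change (hydroxycarbamoyl in place of 3-(hydroxycarbamoyl)propyl on a saturated chain carbon, two bonds along the chain from an aromatic nitrogen). In words, this is hydroxycarbamoyl in place of 3-(hydroxycarbamoyl)propyl on a saturated chain carbon, two bonds along the chain from an aromatic nitrogen.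

Going by the values given here, one measured step bears on it: an at least 9.0-fold higher number from compound 1 to compound 2 (0.95 log units; beyond the scatter). That step is the same replacement, made five bonds along the chain from an aromatic nitrogen, and it went beyond the scatter towards higher numbers. Its true size is open, since it ends at a limit. A further move towards higher numbers is expected in this assay, of uncertain size, and a second report as a limit is the likeliest outcome.

The expected step is a step that the limit leaves unreadable from compound 2 to compound 3. For compound 3 the estimated value is 200000 nM, with an expected range of 70000 nM to 600000 nM.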

Compound 3, half-maximal inhibitory concentration: > 150000 nM
Compound 3: only a limit was reported (the forecaster's own chance of this, stated with the estimate: 85%); the middle value is on the limit's open side.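

Compound 3 is reported in this assay only as a limit of the assay, not as a number: the limit of > 150000 nM in this assay, at which 1 of the 3 values shown sits.

The shorter 2-(hydroxycarbamoyl)ethyl chain therefore gives no measurable value here, which extends the picture from compound 2 down to the shortest chain shown. Its comparison with the longest chain now reads as an at least 13-fold higher number from compound 1 to compound 3 (1.13 log units; beyond the scatter), a large step beyond the scatter and a larger minimum than the earlier step to compound 2 could show. The step from compound 2 to compound 3 cannot be read, since both of its ends are limits, so these data do not say whether the change from the 5-(hydroxycarbamoyl)pentyl chain to the 2-(hydroxycarbamoyl)ethyl chain alters the read-out at all.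

From the compounds shown here alone, compound 1 remains the only one of the three with a measured number, so the true size of both steps away from it stays open. Also open, going by these compounds, is how a chain longer than that of compound 1, or a carboxylic acid in place of the hydroxycarbamoyl end, would read on the shared core.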